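This account rests on a few compounds, and the source may have more. Where it says the series, first, only, none or still open, it means among the compounds named here.

Of the compounds shown here, three sharing one core have been measured so far. Compound 1 `C[C@H]1C[C@H]1C(=O)N1CC2CNCC2C1` gives 2000 nM in an assay on CHO cells for displacement of a labelled ligand from Neuronal acetylcholine receptor; alpha3/beta4 (Homo sapiens), read by scintillation counting, with a stated time of 2 h; on this read-out higher numbers stand for weaker inhibition and lower numbers for stronger inhibition. Compound 2 `CC(=O)N1CC2CNCC2C1` gives 14000 nM in this assay. Compound 3 `CCC(=O)N1CC2CNCC2C1` gives 2100 nM in this assay, which places compound 3 second highest of the three numbers: its nearest neighbour is compound 1, with a step within the scatter a 1.1-fold higher number from compound 1 to compound 3 (0.02 log units; within the scatter), and its furthest is compound 2 a 6.7-fold lower number from compound 2 to compound 3 (0.82 log units; beyond the scatter).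

Compound 4 `COC(=O)N1CC2CNCC2C1` differs from compound 3 in one place: methoxy in place of ethyl on a carbonyl carbon. Among the compounds with values here, two measured steps bear on this position. The step of a 6.7-fold lower number from compound 2 to compound 3 (0.82 log units; beyond the scatter) shows that extending the acyl chain by one carbon brings a modest gain, while the step of a 1.1-fold higher number from compound 1 to compound 3 (0.02 log units; within the scatter) shows that ethyl and 2-methylcyclopropyl are indistinguishable here. Within the data shown here, neither step exchanges a carbon for an oxygen on the carbonyl carbon, so there is no direct precedent for a methoxy at this place. Since the group entering has the same heavy-atom count as the group leaving, and groups of this size gave numbers close to compound 3, the expected step is small, a 1.4-fold higher number from compound 3 to compound 4 (0.15 log units; within the scatter), with no firm direction beyond the scatter. The estimate for compound 4 in this assay is therefore 3000 nM, within a range from 1000 nM to 10000 nM.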

Compound 4, inhibition constant: 14000 nM
Compound 4: middle estimate off by 4.7-fold (0.67 log units), on the low side, outside the stated range (above it).
By their numbers in this assay, from the lowest: compounds 1 and 3 (each within the scatter of the next); then compounds 2 and 4 (each within the scatter of the next).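

In this assay, within the data shown here, exchanging ethyl for methoxy on a carbonyl carbon is not a neutral swap (a 6.7-fold higher number from compound 3 to compound 4 (0.82 log units; beyond the scatter)), so two groups with the same heavy-atom count are clearly told apart at this place, something the earlier compounds, all with carbon groups here, could not show. Methoxy reads level with methyl (no change at the digits printed from compound 2 to compound 4 (within the scatter)) and stands well apart from 2-methylcyclopropyl (a 7.0-fold higher number from compound 1 to compound 4 (0.85 log units; beyond the scatter)), so across these four compounds heavy-atom count alone does not set the number: compound 4 matches compound 3 in that count, yet its value falls with that of compound 2. Nothing available accounts for this difference between methoxy and ethyl.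

The compounds shown leave open whether a longer alkoxy group such as ethoxy would bring the number back towards that of compound 3, or whether an amine such as dimethylamino on the carbonyl carbon would read with compound 4. Among these compounds, also open is how a longer chain such as butyl would read, given that ethyl and 2-methylcyclopropyl are the only groups here with the lower numbers.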